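Chloro for Methoxy: Estimating Compound 4

This account rests on a few compounds, and the source may have more. Where it says the series, first, only, none or still open, it means among the compounds named here.

Compound 1 `COc1ncc(-c2ccc3c(c2)N(c2ccc(C)cc2)C(=O)CO3)cc1NS(=O)(=O)c1ccc(F)cc1`: 15400 nM
Compound 2 `COc1ccc(N2C(=O)COc3ccc(-c4cnc(OC)c(NS(=O)(=O)c5ccc(F)cc5)c4)cc32)cc1`: 8260 nM
Compound 3 `COc1ncc(-c2ccc3c(c2)NC(=O)CO3)cc1NS(=O)(=O)c1ccc(F)cc1`: 32300 nM

In a functional assay on MCF7 cells (Homo sapiens) for antiproliferative activity, read by MTT assay, with a stated time of 72 h (a higher number here means a weaker inhibitor, a lower number a stronger inhibitor), compound 2 gives the lowest of the three numbers; compound 1 lies within the scatter of it, while compound 3 stands apart (a 3.9-fold higher number from compound 2 to compound 3 (0.59 log units; beyond the scatter)). Compound 4 `COc1ccc(N2C(=O)COc3ccc(-c4cnc(Cl)c(NS(=O)(=O)c5ccc(F)cc5)c4)cc32)cc1` differs from compound 2 only by chloro in place of methoxy on an aromatic carbon. Going by the values given here, none of the measured steps touches this position: a 1.9-fold lower number from compound 1 to compound 2 (0.27 log units; within the scatter), a 2.1-fold higher number from compound 1 to compound 3 (0.32 log units; beyond the scatter) and a 3.9-fold higher number from compound 2 to compound 3 (0.59 log units; beyond the scatter) all concern the group on the amide-type nitrogen in the ring. Without a direct precedent, the expected step in this assay is none beyond the scatter, though a modest move in either direction cannot be ruled out. Compound 4 is therefore estimated at 8000 nM, within a range of 3000 nM to 25000 nM, the expected step being a 1.0-fold lower number from compound 2 to compound 4 (0.01 log units; within the scatter).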

Compound 4, half-maximal inhibitory concentration: 36000 nM
For compound 4 the middle estimate is 4.5-fold (0.65 log units) below the measured one, outside the stated range (above it).
By their numbers in this assay, from the lowest: compounds 2 and 1 (each within the scatter of the next); then compounds 3 and 4 (each within the scatter of the next).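

In this assay, the position next to the ring nitrogen proves sensitive to substitution, as chloro in place of methoxy gives a 4.4-fold higher number from compound 2 to compound 4 (0.64 log units; beyond the scatter) with the rest of the molecule unchanged. A single small exchange here thus moves the number about as far as losing the whole 4-methoxyphenyl group, a 3.9-fold higher number from compound 2 to compound 3 (0.59 log units; beyond the scatter) on the amide-type nitrogen. No measurement shown accounts for this step.

The compounds shown leave open how an amine or a longer ether such as ethoxy would fare at this position. They also leave open whether chloro has the same effect with the 4-methylphenyl group of compound 1 in place.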